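The compounds below may be only part of what the source reports. "The series", "measured", "known", "first", "only" and "open" are said of these compounds alone.

Compound 2 `CC(=O)c1nn(-c2ccccc2)/c(=N/c2nc(-c3c(C)n(C)n(-c4ccccc4)c3=O)cs2)s1` sits at a limit in a functional assay on MCF7 cells (Homo sapiens) for cytotoxicity, read by sulforhodamine B assay, with a stated time of 72 h; a lower number here means a stronger inhibitor, a higher number a weaker inhibitor: compound 2 gives > 100000 nM, a limit of the assay rather than a number. Compound 1 `Cc1c(-c2csc(/N=c3\sc(-c4ccccc4)nn3-c3ccccc3)n2)c(=O)n(-c2ccccc2)n1C` also gives a limit; in this assay compound 1 gives > 100000 nM. The step that the two limits leave unreadable from compound 1 to compound 2 cannot be read, since both values sit at the same limit (the limit of > 100000 nM in this assay, at which 2 of the 2 values shown sit). Compound 3 `CCOC(=O)c1nn(-c2ccccc2)/c(=N/c2nc(-c3c(C)n(C)n(-c4ccccc4)c3=O)cs2)s1` differs from compound 2 by ethoxy in place of methyl on a carbonyl carbon. No measured step bears on this change, as the only step shown is unreadable. Compound 3 is therefore expected to stay at the limit, an estimated step that the limit leaves unreadable from compound 2 to compound 3 of no readable size. The estimate for compound 3 is 150000 nM, with a range from 40000 nM to 1000000 nM.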

Compound 3, half-maximal inhibitory concentration: > 100000 nM
Compound 3 ended at the assay's limit; the forecaster's own chance of this, stated with the estimate: 85%; the middle value does not contradict the limit.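

Within the data shown here, no step among compound 1, compound 2 and compound 3 can be read, since all three give a limit rather than a number: the limit of > 100000 nM in this assay, at which 3 of the 3 values shown sit. The compounds shown leave open how the three compare, and whether any group at this place would give a readable number.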